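Nitrone series on the triazole core: benzyl versus tert-butyl

The compounds below may be only part of what the source reports. "The series", "measured", "known", "first", "only" and "open" are said of these compounds alone.

Measured so far:
- compound 1 `COc1ccc(-n2cc(/C=[N+](\[O-])Cc3ccccc3)nn2)cc1`: > 100000 nM
- compound 2 `CCCCCCCCn1cc(/C=[N+](\[O-])Cc2ccccc2)nn1`: > 100000 nM
- compound 3 `COc1ccc(-n2cc(/C=[N+](\[O-])C(C)(C)C)nn2)cc1`: 23100 nM

The compounds were tested in a functional assay on MDA-MB-231 cells (Homo sapiens) for inhibition, read by MTT assay, with a stated time of 24 h; a higher number here means a weaker inhibitor, a lower number a stronger inhibitor. For compound 1 the value > 100000 nM is a limit of the assay, not a number. For compound 2 the value > 100000 nM is likewise a limit. Compound 3 gives a numerical value, 23100 nM, in this assay.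

The change from compound 1 to compound 3 is tert-butyl in place of benzyl on a double-bonded nitrogen. It produced an at least 4.3-fold lower number from compound 1 to compound 3 (0.63 log units; beyond the scatter). Because (the limit of > 100000 nM in this assay, at which 2 of the 3 values shown sit), the size of this step is known only as a lower bound.

Compound 4 `CCCCCCCCn1cc(/C=[N+](\[O-])C(C)(C)C)nn1` has not yet been measured in this assay. It carries the same change relative to compound 2, namely (tert-butyl in place of benzyl on a double-bonded nitrogen). The difference between the core of compound 1 and the core of compound 2 is not broken down here.

For compound 4 the step from compound 2 is expected to be an at least 2.5-fold lower number from compound 2 to compound 4 (0.39 log units; beyond the scatter), an expectation resting on the parallel step an at least 4.3-fold lower number from compound 1 to compound 3 (0.63 log units; beyond the scatter) seen with compound 1 and compound 3. From the compounds shown here alone, since compound 2 sits at a limit, whether compound 4 yields a number at all remains open. The estimate for compound 4 in this assay is 40000 nM, with a range from 15000 nM to 150000 nM.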

Compound 4, half-maximal inhibitory concentration: 29700 nM
Estimate against measurement, compound 4: 1.3-fold (0.13 log units) above; the range from low to high includes it.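

In this assay, tert-butyl in place of benzyl on a double-bonded nitrogen carries over to the second core in the same direction, with an at least 3.3-fold lower number from compound 2 to compound 4 (0.52 log units; beyond the scatter). Set beside the step on the first core, the result reads: the same change on two cores in this assay, an at least 4.3-fold lower number (0.63 log units; beyond the scatter) from compound 1 to compound 3 and an at least 3.3-fold lower number (0.52 log units; beyond the scatter) from compound 2 to compound 4; the limit leaves it open whether they differ. The value of compound 2, > 100000 nM, is a limit of the assay and not a number, and compound 1 also stands at a limit, so both steps are lower bounds that show a shared direction on these two cores but neither a true size nor any agreement in size: the limit of > 100000 nM in this assay, at which 2 of the 4 values shown sit.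

The series shown here covers only benzyl and tert-butyl on that nitrogen, so it remains open how an intermediate group such as isopropyl or cyclohexyl, or a tert-butyl analogue carrying an amine or a carboxylic acid, would read in this assay. Among these compounds, the separate contribution of the difference between the core of compound 1 and the core of compound 2 also remains open, as does whether the step holds on a core bearing a longer chain than the one in compound 4.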